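Amide for urea: compound 3 on the shared core

This account rests on a few compounds, and the source may have more. Where it says the series, first, only, none or still open, it means among the compounds named here.

Among the measured compounds shown here, compound 2 `CNC(=O)c1cc(Oc2ccc3nc(NC(=O)Nc4ccc(Cl)cc4)sc3c2)ccn1` sits at the lower of the two numbers measured so far: in a functional assay on SK-BR-3 cells (Homo sapiens) for inhibition, read by MTT assay, with a stated time of 2 days, tested at 100 uM (on this read-out higher numbers stand for more inhibition of growth at the one concentration tested and lower numbers for less inhibition of growth), compound 2 gives 77.4%, while compound 1 `CNC(=O)c1cc(Oc2ccc3nc(NC(=O)c4ccc(Cl)cc4Cl)sc3c2)ccn1` gives 81% in this assay. For the measured compounds named here, the only step recorded between measured compounds is a number 3.6 percentage points lower from compound 1 to compound 2 (within the scatter), so the two stand together. The new compound 3 `CNC(=O)c1cc(Oc2ccc3nc(NC(=O)c4cc(Cl)cc(Cl)c4)sc3c2)ccn1` differs from compound 2 by 3,5-dichlorophenyl in place of (4-chlorophenyl)amino on a carbonyl carbon. Going by the values given here, that step bears on the one measured step, which swapped a dichlorophenyl amide for a chlorophenyl urea and moved the read-out in this assay by an amount within the scatter, a number 3.6 percentage points lower from compound 1 to compound 2 (within the scatter). Going back to a dichlorophenyl amide is therefore expected to move the read-out little, with a step of about a number 2.6 percentage points higher from compound 2 to compound 3 (within the scatter) in this assay. Compound 3 is estimated to give about 80% in this assay, with a plausible range from 65% to 92%.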

Compound 3, percent growth inhibition at one concentration: 84.3%
Estimate against measurement, compound 3: 4.3 percentage points below, within the range that was stated.
By their numbers in this assay, from the lowest: compounds 2, 1 and 3 (each within the scatter of the next).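

In this assay, the change of a urea back to an amide, with a second chlorine added, reads a number 6.9 percentage points higher from compound 2 to compound 3 (within the scatter), and the change of chlorine pattern within the amides reads a number 3.3 percentage points higher from compound 1 to compound 3 (within the scatter). On this carbonyl carbon, 3,5-dichlorophenyl, 2,4-dichlorophenyl and (4-chlorophenyl)amino therefore read alike at the one concentration tested, whether or not the group carries the hydrogen-bond donor of (4-chlorophenyl)amino or either arrangement of two chlorines. No measurement available here offers an explanation for this sameness.

The compounds shown leave open what a group without a phenyl ring, such as cyclohexyl or morpholine, or a carboxylic acid on the phenyl ring, would do at this position. They also leave open whether these three compounds would still stand together at lower concentrations.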